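Halogen pattern on the aryl arm: compound 3 to compound 4

The source may hold more compounds than are shown below. What is called first, only, known or untested is meant among the compounds shown, and "the series" means these compounds.

Going by the values given here, compound 3 `C=CCn1c(=O)/c(=C\c2cccc(Cl)c2Cl)[nH]c(=O)/c1=C\c1ccccc1OC` has the lowest number of the three measured members in a functional assay on HL-60 cells (Homo sapiens) for cytotoxicity, read by CCK-8 assay, with a stated time of 72 h (on this read-out lower numbers stand for stronger inhibition and higher numbers for weaker inhibition), where compound 3 gives 2000 nM. Its nearest neighbour is compound 2 `C=CCn1c(=O)/c(=C\c2ccccc2C(F)(F)F)[nH]c(=O)/c1=C\c1ccccc1OC`, which in this assay gives 4600 nM; the gap is a 2.3-fold lower number from compound 2 to compound 3 (0.36 log units; beyond the scatter). Furthest off is compound 1 `C=CCn1c(=O)/c(=C\c2ccccc2F)[nH]c(=O)/c1=C\c1ccccc1OC`, which in this assay gives 18500 nM; that gap is a 9.3-fold lower number from compound 1 to compound 3 (0.97 log units; beyond the scatter). The remaining measured step is a 4.0-fold lower number from compound 1 to compound 2 (0.60 log units; beyond the scatter).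

Compound 4 `C=CCn1c(=O)/c(=C\c2cc(Br)ccc2F)[nH]c(=O)/c1=C\c1ccccc1OC` differs from compound 3 by 5-bromo-2-fluorophenyl in place of 2,3-dichlorophenyl on a double-bonded chain carbon bound to an aromatic carbon. Both measured steps from compound 1 bear on this: replacing the 2-fluorophenyl of compound 1 by a ring carrying a trifluoromethyl or two chlorines lowered the number by a modest amount, a 4.0-fold lower number from compound 1 to compound 2 (0.60 log units; beyond the scatter) and a 9.3-fold lower number from compound 1 to compound 3 (0.97 log units; beyond the scatter). Among the compounds with values here, compound 4 keeps the 2-fluorophenyl substitution of compound 1 and adds a bromine, so it is expected to sit between compound 1 and compound 3 rather than beyond compound 3; no measured step covers a bromine directly. The expected step is therefore a modest rise in the number, a 2.5-fold higher number from compound 3 to compound 4 (0.40 log units; beyond the scatter). Compound 4 is estimated to give 5000 nM in this assay, with a range from 1500 nM to 16000 nM.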

Compound 4, half-maximal inhibitory concentration: 17400 nM
Estimate against measurement, compound 4: 3.5-fold (0.54 log units) below; the whole stated range lies below it.
By their numbers in this assay, from the lowest: compound 3; then compound 2; then compounds 4 and 1 (each within the scatter of the next).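

On the 2-fluorophenyl arm in this assay, bromo in place of hydrogen on an aromatic carbon gives no readable shift (a 1.1-fold lower number from compound 1 to compound 4 (0.03 log units; within the scatter)), so at this place the added bromine does not carry the arm towards the lower numbers seen with compound 2 and compound 3. Having more than one halogen on the ring is therefore not enough on its own: 2,3-dichlorophenyl and 5-bromo-2-fluorophenyl are both dihalogenated, yet the exchange gives a clear rise (an 8.7-fold higher number from compound 3 to compound 4 (0.94 log units; beyond the scatter)), and the exchange for 2-(trifluoromethyl)phenyl also gives a rise (a 3.8-fold higher number from compound 2 to compound 4 (0.58 log units; beyond the scatter)). No measurement on hand accounts for these gaps.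

The compounds shown do not separate the contributions of the chlorines on the 2,3-dichlorophenyl arm, and they leave unclear whether the fluorine of compound 4 or the placing of its bromine limits that arm. From the compounds shown here alone, how a nitrile or a carboxylic acid on this aryl arm would read remains open, as does a longer chain in place of the allyl group on the shared core.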